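A few compounds are considered here, and "the series" means these few. Any claim that something is new, unique, unknown or untested is made for them only; others in the source may bear on it.

Measured compounds:
- compound 1, `Clc1ccncc1C1=CC2CNCC(C1)C2`, in an in vitro functional assay on SH-EP1 cells for agonist activity at Neuronal acetylcholine receptor; alpha4/beta2 (Homo sapiens), read by FLIPR and calcium flux (a lower number here means that less compound is needed, a higher number that more compound is needed for the effect), gives > 10000 nM
- compound 2, `Clc1ccc(C2=CC3CNCC(C2)C3)cn1`, in this assay gives 35 nM

The value of compound 1 in this assay is a limit of the assay, not a number; this is the situation described by the limit of > 10000 nM in this assay, at which 1 of the 2 values shown sits. Going by the values given here, compound 2 is therefore the only compound of the pair with a measured number in this assay, and it stands alone among the values shown. Among the compounds with values here, no step between two measured compounds is available to guide expectations.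

Compound 3, `Fc1ccc(C2=CC3CNCC(C2)C3)cn1`, is not yet measured in this assay. It differs from compound 2 by fluoro in place of chloro on an aromatic carbon. With nothing measured to anchor this exchange, the step is expected to be small, a 1.7-fold higher number from compound 2 to compound 3 (0.23 log units; within the scatter), and may well fall within the scatter of repeated measurements. Compound 3 is estimated at 60 nM in this assay, with a range from 15 nM to 250 nM.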

Compound 3, half-maximal effective concentration: 85 nM
Beside the measured number, compound 3's estimate is 1.4-fold (0.15 log units) below it, within the range that was stated.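

Fluoro in place of chloro, on the aromatic carbon next to the ring nitrogen, gives the first step in the series that can be read in this assay (a 2.4-fold higher number from compound 2 to compound 3 (0.39 log units; beyond the scatter)). The step is modest yet beyond the scatter: this position accepts either halogen with agonist activity retained, and chloro gives the lower number of the pair. Nothing measured here bears on the reason for this difference.

From the compounds shown here alone, whether the activity holds with a group other than a halogen at this carbon, such as methoxy, an amine or a nitrile, stays open. Going by these compounds, compound 1 gives (> 10000 nM), a limit of the assay and not a number, and how fluoro would read on that compound also stays open.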